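The source may report more compounds than this note shows. Statements on the series, on what has been measured and on what is new or still open speak of the compounds shown alone.

Measured compounds:
compound 1 `CCN(CCCCCCOc1ccc(C(=O)/C=C/c2ccc(N(C)C)cc2)c(O)c1)Cc1ccccc1`, in an assay on isolated protein for inhibition of Amine oxidase [flavin-containing] B (Homo sapiens) (on this read-out lower numbers stand for stronger inhibition and higher numbers for weaker inhibition), compound 1 gives 2100 nM;
compound 2 `CCN(CCCOc1ccc(C(=O)/C=C/c2ccc(N(C)C)cc2)c(O)c1)Cc1ccccc1`, compound 2 gives 13100 nM;
compound 3 `CCN(CCCCCCOc1ccc(C(=O)/C=C/c2ccc(N(C)C)cc2)c(O)c1)Cc1ccccc1OC`, compound 3 gives 700 nM.

Compound 2 stands at the highest number of the three, so it is the weakest inhibitor of the measured set. Its nearest neighbour is compound 1, which differs only in carrying a longer saturated chain between the ring oxygen and the amine; the two values show a clear gap in favour of compound 1. Within the data shown here, the only step between single-change pairs, a 3.0-fold lower number from compound 1 to compound 3 (0.48 log units; beyond the scatter), concerns a methoxy on the benzyl ring and does not touch the chain.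

Compound 4 `CCN(CCCCOc1ccc(C(=O)/C=C/c2ccc(N(C)C)cc2)c(O)c1)Cc1ccccc1` is reached from compound 2 by (benzyl(ethyl)amino)methyl in place of benzyl(ethyl)amino on a saturated chain carbon, three bonds along the chain from an oxygen on an aromatic ring, a lengthening of the chain by one unit towards that of compound 1. Among the measured compounds shown here, no measured pair isolates a one-unit chain change, so the expectation rests only on the values of compound 2 and compound 1: a lower number than compound 2 is expected, of moderate size, not reaching compound 1. The expected step is a 2.0-fold lower number from compound 2 to compound 4 (0.30 log units; within the scatter). For compound 4 the estimate is 6500 nM, with a range from 2500 nM to 15000 nM.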

Compound 4, half-maximal inhibitory concentration: 8900 nM
For compound 4 the middle estimate is 1.4-fold (0.14 log units) below the measured one; the measured number falls inside the stated range.
By their numbers in this assay, from the lowest: compound 3; then compound 1; then compounds 4 and 2 (each within the scatter of the next).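

In this assay the one-unit lengthening gives a 1.5-fold lower number from compound 2 to compound 4 (0.17 log units; within the scatter) and so is not resolved on its own at this saturated chain carbon. The step back from the longest chain, benzyl(ethyl)amino in place of 2-(benzyl(ethyl)amino)ethyl, gives a 4.2-fold higher number from compound 1 to compound 4 (0.63 log units; beyond the scatter) and is beyond the scatter, so among these three chains the resolved difference lies on the side of compound 1. Nothing available here explains this uneven spread along the chain.

As far as these compounds go, whether a chain longer than that of compound 1 lowers the number further remains open, as does the effect of a methyl in place of the ethyl. It is also unknown whether the methoxy on the benzyl ring of compound 3 would give a comparable step on the shorter chains.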